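Cytotoxicity notes: propyl to benzyl on the ring nitrogen

The source may hold more compounds than are shown below. What is called first, only, known or untested is meant among the compounds shown, and "the series" means these compounds.

The series is built on a shared acetylated sugar chain linked to an oxindole-type core, shown as compound 1 `CC(=O)OC[C@H]1O[C@@H](CC(=O)CC2(O)C(=O)N(Cc3ccc(Br)cc3)c3ccc(Cl)cc32)[C@H](OC(C)=O)[C@@H](OC(C)=O)[C@@H]1OC(C)=O`, compound 2 `CCCN1C(=O)/C(=C\C(=O)C[C@@H]2O[C@H](COC(C)=O)[C@@H](OC(C)=O)[C@H](OC(C)=O)[C@H]2OC(C)=O)c2ccccc21`, compound 3 `CCCN1C(=O)/C(=C\C(=O)C[C@@H]2O[C@H](COC(C)=O)[C@@H](OC(C)=O)[C@H](OC(C)=O)[C@H]2OC(C)=O)c2cc(Cl)ccc21` and compound 4 `CC(=O)OC[C@H]1O[C@@H](CC(=O)/C=C2\C(=O)N(Cc3ccccc3)c3ccc(Cl)cc32)[C@H](OC(C)=O)[C@@H](OC(C)=O)[C@@H]1OC(C)=O`. For compound 1 the result in an ADME assay on Vero cells (Chlorocebus sabaeus) for cytotoxicity, read by resazurin assay, with a stated time of 72 h (a lower number here means that less compound is tolerated, a higher number that more compound is tolerated), is "not determined" (no result reported). In this assay compound 2 gives 125000 nM and compound 3 gives 95600 nM; the step of a 1.3-fold lower number from compound 2 to compound 3 (0.12 log units; within the scatter) stays within the scatter. Within the data shown here, compound 3 therefore holds the lowest of the two numbers, but its only neighbour, compound 2, sits within the scatter of it, so no order between them can be claimed.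

The change to compound 4 is phenyl in place of ethyl on a saturated chain carbon bound to an amide-type nitrogen in a ring. Among the measured compounds shown here, no measured step in this assay alters the group on that nitrogen; the single measured step concerns a chloro on the aromatic ring and was within the scatter, so it gives no direct guidance. With nothing pointing either way, compound 4 is expected to show no step beyond the scatter, a 1.1-fold lower number from compound 3 to compound 4 (0.05 log units; within the scatter). Compound 4 is accordingly estimated at 85000 nM in this assay, with a range from 40000 nM to 180000 nM.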

Compound 4, half-maximal cytotoxic concentration: 91200 nM
Compound 4: the middle estimate sits 1.1-fold (0.03 log units) below what was measured; low and high end bracket the measured number.
By their numbers in this assay, from the lowest: compounds 4, 3 and 2 (each within the scatter of the next).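

Phenyl in place of ethyl on a saturated chain carbon bound to an amide-type nitrogen in a ring is the first measured change at this position, and this assay records a 1.0-fold lower number from compound 3 to compound 4 (0.02 log units; within the scatter). Propyl and benzyl on the ring nitrogen therefore cannot be told apart here, even though benzyl brings in a six-membered aromatic ring of carbon only, whereas the earlier step concerned only chloro on the aromatic ring. No supporting measurement bears on this result.

On these data alone, whether an amine, a carboxylic acid or a longer chain on that nitrogen would give a step beyond the scatter remains open. Also open, as far as these compounds go, is whether free hydroxyl groups in place of the acetates on the sugar chain would change the picture in this assay.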